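Swapping difluoromethoxy for carbamoyl on an aromatic carbon

The source may hold more compounds than are shown below. What is called first, only, known or untested is meant among the compounds shown, and "the series" means these compounds.

Measured in a physicochemical assay for solubility, using the shake flask method, in simulated intestinal fluid, measured as kinetic solubility, with a stated time of 2 h, at 25 degrees C, at pH 6.5; on this read-out lower numbers stand for lower solubility and higher numbers for higher solubility
- Compound 1 `Cc1noc(-c2nc(C)c3c(c2N)C(=O)N(CC2CCOCC2)C3=O)n1` gives 5700 nM
- Compound 2 `Cc1noc(-c2nc(C)c3c(c2N)C(=O)N(Cc2ccc(OC(F)F)cc2)C3=O)n1` gives < 5000 nM (a limit, not a number)

Compound 2 has no exact number, so it stands at the limit of < 5000 nM in this assay, at which 1 of the 2 values shown sits. Compound 3 `Cc1noc(-c2nc(C)c3c(c2N)C(=O)N(Cc2ccc(C(N)=O)cc2)C3=O)n1` differs from it by carbamoyl in place of difluoromethoxy on an aromatic carbon, with carbamoyl in place of difluoromethoxy on an aromatic carbon. Within the data shown here, the only measured step nearby is an at least 1.1-fold lower number from compound 1 to compound 2 (0.05 log units; that floor lies within the scatter), and it swaps a whole group, so it offers weak guidance. No step beyond the scatter is therefore expected in this assay, in either direction. The expected step is a number no lower from compound 2 to compound 3 (the limit leaves the size open). Compound 3 is estimated at 5000 nM, with an expected range of 2500 nM to 12000 nM.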

Compound 3, solubility: < 5000 nM
Compound 3: only a limit was reported; the forecaster's own chance of this, stated with the estimate: 55%; the middle value sits exactly at the limit.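

Compound 3, which carries a hydrogen-bond donor that compound 2 lacks, is still reported only as a limit in this assay. The swap of difluoromethoxy for carbamoyl on this aromatic carbon cannot be read, because both compounds stop at one limit: the limit of < 5000 nM in this assay, at which 2 of the 3 values shown sit. With 4-carbamoylphenyl in place of oxan-4-yl, the comparison gives an at least 1.1-fold lower number from compound 1 to compound 3 (0.05 log units; that floor lies within the scatter). On these data alone, how far compound 2 and compound 3 lie under that limit stays open. Also open, as far as these compounds go, is whether an amine or a carboxylic acid on this aromatic carbon would give an exact reading in this assay.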